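Para-chloro on the distal phenyl of compound 3

The source may report more compounds than this note shows. Statements on the series, on what has been measured and on what is new or still open speak of the compounds shown alone.

Three compounds share a lactam core with a carboxylic acid side chain and a diaryl tail, and all three were tested in an assay on CHO cells for displacement of a labelled ligand from prostaglandin E2 receptor EP4 subtype (Mus musculus), read by scintillation counting, with a stated time of 60 min; a higher number here means a weaker inhibitor, a lower number a stronger inhibitor. Compound 1 `O=C(O)CCCSCCN1C(=O)CC[C@@H]1/C=C/[C@@H](O)Cc1cccc(-c2ccc3[nH]ccc3c2)c1` gives 0.28 nM. Compound 2 `O=C(O)CCCSCCN1C(=O)CC[C@@H]1/C=C/[C@@H](O)Cc1cccc(-c2nc3ccccc3s2)c1` gives 0.36 nM, and a 1.3-fold higher number from compound 1 to compound 2 (0.11 log units; within the scatter). Compound 3 `O=C(O)c1csc(SCCN2C(=O)CC[C@@H]2/C=C/[C@@H](O)Cc2cccc(-c3ccccc3)c2)n1` gives 0.94 nM, the highest of the three numbers, beyond the scatter from both compound 1 and compound 2.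

Compound 4 `O=C(O)c1csc(SCCN2C(=O)CC[C@@H]2/C=C/[C@@H](O)Cc2cccc(-c3ccc(Cl)cc3)c2)n1` differs from compound 3 by chloro in place of hydrogen on an aromatic carbon. Within the data shown here, no measured step shows the effect of a substituent added to the phenyl; the one measured step, from an indolyl to a benzothiazolyl tail, lies within the scatter and concerns a different change. With nothing to point either way, compound 4 is expected to sit close to compound 3, with a 1.0-fold lower number from compound 3 to compound 4 (0.02 log units; within the scatter) not beyond the scatter in this assay. Compound 4 is therefore estimated at 0.9 nM, with a range from 0.4 nM to 2 nM.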

Compound 4, inhibition constant: 0.81 nM
Estimate against measurement, compound 4: 1.1-fold (0.05 log units) above; the measured number falls inside the stated range.
By their numbers in this assay, from the lowest: compounds 1 and 2 (each within the scatter of the next); then compounds 4 and 3 (each within the scatter of the next).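

In this assay, replacing phenyl with 4-chlorophenyl gives a 1.2-fold lower number from compound 3 to compound 4 (0.06 log units; within the scatter), the only step shown in which a substituent enters this ring. Among these compounds, it shows that, in this pair, a chloro on an aromatic carbon para to a large group leaves compound 4 within the scatter of compound 3, which the earlier compounds could not show. Nothing measured here bears on why the two numbers stand so close.

Going by these compounds, whether a methoxy, an amine or a carboxylic acid at the same place would also stay within the scatter remains open, as does the effect of chloro elsewhere on this ring. The compounds shown also leave open whether chloro would behave the same way on the aryl tails of compound 1 and compound 2.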